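Amidrazone thiosemicarbazides against MCF7: methyl removal step

The source may report more compounds than this note shows. Statements on the series, on what has been measured and on what is new or still open speak of the compounds shown alone.

Measured so far:
compound 1, `N/C(=N\NC(=S)N1CCSCC1)c1ccccn1`, 72.6%
compound 2, `Cc1cccc(/C(N)=N/NC(=S)N2CCCC2)n1`, 40.1%

In a functional assay on MCF7 cells (Homo sapiens) for cytotoxicity, read by MTT assay, with a stated time of 72 h, tested at 30 uM (a higher number here means more inhibition of growth at the concentration tested, a lower number less inhibition of growth), compound 2 stands lowest of the two numbers; compound 1 sits higher by a margin beyond the scatter, but the two differ in more than one place, so their gap is read only as what the two values show. Compound 3, `N/C(=N\NC(=S)N1CCCC1)c1ccccn1`, is not yet measured. It differs from compound 2 by hydrogen in place of methyl on an aromatic carbon. Within the data shown here, no step between measured compounds isolates this change. Compound 1, which also lacks the methyl, gives 72.6%, so a modest rise is expected, a number 13.9 percentage points higher from compound 2 to compound 3 (beyond the scatter), though it could fall within the scatter. Compound 3 is estimated at 54%, expected between 35% and 74%.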

Compound 3, percent growth inhibition at one concentration: 54.6%
Compound 3: middle estimate off by 0.6 percentage points, on the low side; the range from low to high includes it.
By their numbers in this assay, from the lowest: compound 2; then compound 3; then compound 1.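

In this assay, hydrogen in place of methyl on an aromatic carbon next to the ring nitrogen gives a number 14.5 percentage points higher from compound 2 to compound 3 (beyond the scatter) with the pyrrolidin-1-yl group unchanged, so this position affects growth inhibition in this pair. With that aromatic carbon unsubstituted, pyrrolidin-1-yl in place of thiomorpholin-4-yl on the thiocarbonyl carbon gives a number 18 percentage points lower from compound 1 to compound 3 (beyond the scatter) as a separate step. Nothing available explains either step.

Open, going by these compounds, is how an amine or an ethyl chain on this aromatic carbon would compare with hydrogen and methyl. Also open, on these data alone, is whether the methyl step holds with thiomorpholin-4-yl on the thiocarbonyl carbon.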